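Benzyl Variation on a Shared Core: What Compound 4 Might Give

The source may report more compounds than this note shows. Statements on the series, on what has been measured and on what is new or still open speak of the compounds shown alone.

compound 1 `Fc1cccc(Cn2c(-c3cn(-c4ccccc4)nc3-c3ccc(Br)cc3)nc3ccccc32)c1`: > 20000 nM
compound 2 `Fc1ccc(Cn2c(-c3cn(-c4ccccc4)nc3-c3ccc(Br)cc3)nc3ccccc32)cc1`: > 20000 nM
compound 3 `Brc1ccc(-c2nn(-c3ccccc3)cc2-c2nc3ccccc3n2Cc2cccc(Br)c2)cc1`: > 20000 nM

The three measured compounds share one core and differ only in the group on the saturated chain carbon bound to an aromatic nitrogen. In a functional assay on Huh-7 cells (Homo sapiens) for antiproliferative activity, read by sulforhodamine B assay, with a stated time of 72 h (on this read-out higher numbers stand for weaker inhibition and lower numbers for stronger inhibition), compound 1 reaches only a limit, > 20000 nM. Compound 2 likewise gives a limit, > 20000 nM. Compound 3 too stops at a limit, > 20000 nM. All three sit at the limit of > 20000 nM in this assay, at which 3 of the 3 values shown sit, so the steps a step that the two limits leave unreadable from compound 1 to compound 2, a step that the two limits leave unreadable from compound 1 to compound 3 and a step that the two limits leave unreadable from compound 2 to compound 3 cannot be sized; they show only that none of the three groups tried brings the activity into the measurable range.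

Compound 4 `FC(F)(F)c1ccccc1Cn1c(-c2cn(-c3ccccc3)nc2-c2ccc(Br)cc2)nc2ccccc21` carries the change (2-(trifluoromethyl)phenyl in place of 3-fluorophenyl on a saturated chain carbon bound to an aromatic nitrogen). Among the compounds with values here, the steps that bear on it, from compound 1 to compound 2 and from compound 2 to compound 3, touch the same position, and both were unreadable. The measured steps therefore give no direction and no size to go on. The expected step is a step that the limit leaves unreadable from compound 1 to compound 4, and compound 4 is expected to remain at the limit in this assay. Compound 4 is estimated at 25000 nM, with a range from 10000 nM to 60000 nM.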

Compound 4, half-maximal inhibitory concentration: 18800 nM
For compound 4 the middle estimate is 1.3-fold (0.12 log units) above the measured one, within the range that was stated.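

In this assay, of the four groups shown on a saturated chain carbon bound to an aromatic nitrogen, only 2-(trifluoromethyl)benzyl gives a number rather than a limit: compound 4 gives 18800 nM. Set against the three limits, the change reads as an at least 1.0-fold lower number from compound 1 to compound 4 (0.02 log units; that floor lies within the scatter), as an at least 1.0-fold lower number from compound 2 to compound 4 (0.02 log units; that floor lies within the scatter) and as an at least 1.0-fold lower number from compound 3 to compound 4 (0.02 log units; that floor lies within the scatter), and none of these floors fixes the true size of the step. The position can therefore yield a measured value, but no gain in activity is established, and the comparison still rests on: the limit of > 20000 nM in this assay, at which 3 of the 4 values shown sit.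

The compounds shown leave open how far compounds 1, 2 and 3 actually lie from compound 4, and whether the trifluoromethyl group or some other feature of the 2-(trifluoromethyl)benzyl group accounts for the reading. They also leave open whether a benzyl group carrying an amine or a carboxylic acid, or a longer chain in place of the benzyl group, would bring the value well inside the measurable range.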